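Swapping the oxetane for a cyclobutanol on the ether chain

The source may hold more compounds than are shown below. What is called first, only, known or untested is meant among the compounds shown, and "the series" means these compounds.

compound 1 `CCCCOc1nc(OCC(C)(C)O)c(-c2ccc(S(C)(=O)=O)cc2)cc1CO`: 101 mL/min/kg
compound 2 `CCCCOc1nc(-c2ccc(F)cc2)c(-c2ccc(S(C)(=O)=O)cc2)cc1CO`: 32.2 mL/min/kg
compound 3 `CCCCOc1nc(OCC2(C)COC2)c(-c2ccc(S(C)(=O)=O)cc2)cc1CO`: 89.3 mL/min/kg

In an ADME assay on the whole organism (Mus musculus, strain C57BL/6J) for pharmacokinetics, with a stated time of 24 h, at a dose of 2 mg/kg by the intravenous route (on this read-out higher numbers stand for fast clearance and lower numbers for slow clearance), compound 3 stands level with compound 1 at the high end of the three numbers: the comparison gives a 1.1-fold lower number from compound 1 to compound 3 (0.05 log units; within the scatter) and so separates neither. Compound 2 stands apart, with a 2.8-fold higher number from compound 2 to compound 3 (0.44 log units; beyond the scatter) on the way to compound 3.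

The next structure is compound 4 `CCCCOc1nc(OCC2(O)CCC2)c(-c2ccc(S(C)(=O)=O)cc2)cc1CO` with the change 1-hydroxycyclobutyl in place of 3-methyloxetan-3-yl on a saturated chain carbon bound to an oxygen on an aromatic ring in which 1-hydroxycyclobutyl replaces 3-methyloxetan-3-yl on a saturated chain carbon bound to an oxygen on an aromatic ring.

The closest measured exchange is 3-methyloxetan-3-yl in place of 1-hydroxy-1-methylethyl at that same place, which gave a 1.1-fold lower number from compound 1 to compound 3 (0.05 log units; within the scatter) and nothing larger. The only clear movements replace the whole ether group on an aromatic carbon with 4-fluorophenyl or the reverse, as in a 3.1-fold lower number from compound 1 to compound 2 (0.50 log units; beyond the scatter) and that is a far larger change than the one considered here. This rests on a single comparable exchange, so the support is thin.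

No step beyond the scatter is expected, and the estimated step is a 1.0-fold higher number from compound 3 to compound 4 (0.00 log units; within the scatter) in this reading. The value expected for compound 4 is 90 mL/min/kg with an estimated range (50 mL/min/kg to 160 mL/min/kg).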

Compound 4, clearance: 100 mL/min/kg
Beside the measured number, compound 4's estimate is 1.1-fold (0.05 log units) below it; low and high end bracket the measured number.
By their numbers in this assay, from the lowest: compound 2; then compounds 3, 4 and 1 (each within the scatter of the next).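

In this assay, rearranging the same atoms from 3-methyloxetan-3-yl, with 0 hydrogen-bond donors, to 1-hydroxycyclobutyl, with 1 hydrogen-bond donor, on a saturated chain carbon bound to an oxygen on an aromatic ring separates nothing (a 1.1-fold higher number from compound 3 to compound 4 (0.05 log units; within the scatter)). The hydroxy groups also stay together when 1-hydroxycyclobutyl takes the place of 1-hydroxy-1-methylethyl (a 1.0-fold lower number from compound 1 to compound 4 (0.00 log units; within the scatter)), so neither a hydrogen-bond donor count of 0 or 1 nor the carbon-only ring separates these three ether compounds in this set. Compound 2 alone stands apart, with 4-fluorophenyl in place of the whole ether group on an aromatic carbon (a 3.1-fold higher number from compound 2 to compound 4 (0.49 log units; beyond the scatter)), and no measurement shown here accounts for that gap or for the close grouping of the ether compounds.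

Going by these compounds, with only four compounds, it remains open whether an amine or a carboxylic acid at the end of the ether chain, or a longer chain there, would move the number away from this group. On these data alone, it is also open whether a second aryl group such as plain phenyl would stay close to compound 2 at 32.2 mL/min/kg in this assay.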